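The source may hold more compounds than are shown below. What is called first, only, known or untested is meant among the compounds shown, and "the series" means these compounds.

For the measured compounds named here, in an ADME assay on the whole organism (Mus musculus, strain Swiss) for pharmacokinetics, read by LC-MS, with a stated time of 24 h, at a dose of 20 mg/kg by the oral route (on this read-out higher numbers stand for higher exposure at the dose given and lower numbers for lower exposure), only two compounds have numbers so far. Compound 1 (`Cc1c(Cc2ccc(C(F)(F)F)nc2)c[nH]c1C(=O)NC(C)c1cnn(C)c1`) gives 84900 ng.h/mL, and compound 2 (`Cc1cc(C(C)NC(=O)c2[nH]cc(Cc3ccc(C(F)(F)F)nc3)c2C)no1`) gives 25900 ng.h/mL, the lower of the two. Compound 3 (`Cc1c(Cc2ccc(C(F)(F)F)nc2)c[nH]c1C(=O)NC(C)c1cn[nH]c1`) is still unmeasured in this assay. It differs from compound 2 in one place, on a saturated chain carbon bound to an amide-type nitrogen and a saturated chain carbon: 1H-pyrazol-4-yl in place of 5-methyl-1,2-oxazol-3-yl on a saturated chain carbon bound to an amide-type nitrogen and a saturated chain carbon. Going by the values given here, one measured step bears on this change. This is a 3.3-fold lower number from compound 1 to compound 2 (0.52 log units; beyond the scatter), a modest step beyond the scatter, in which 5-methyl-1,2-oxazol-3-yl took the place of 1-methyl-1H-pyrazol-4-yl. Among the compounds with values here, compound 3 also gives up the 5-methyl-1,2-oxazol-3-yl, but it carries 1H-pyrazol-4-yl rather than the 1-methyl-1H-pyrazol-4-yl of compound 1, and no measured step shows what that difference does on its own. Only part of the measured step is therefore expected to return, so the expected move is upward and smaller, a 1.7-fold higher number from compound 2 to compound 3 (0.24 log units; within the scatter). For compound 3 the estimated value is 45000 ng.h/mL, with an expected range from 14000 ng.h/mL to 120000 ng.h/mL.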

Compound 3, area under the concentration-time curve: 24500 ng.h/mL
Estimate against measurement, compound 3: 1.8-fold (0.26 log units) above; the measured number falls inside the stated range.
By their numbers in this assay, from the lowest: compounds 3 and 2 (each within the scatter of the next); then compound 1.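

In this assay, putting 1H-pyrazol-4-yl in place of 5-methyl-1,2-oxazol-3-yl on the saturated chain carbon gives a 1.1-fold lower number from compound 2 to compound 3 (0.02 log units; within the scatter), so the read-out does not tell these two rings apart at this position. The earlier compounds shown here could not show the methyl on the aromatic nitrogen on its own, but it now has a step of its own: hydrogen in its place gives a 3.5-fold lower number from compound 1 to compound 3 (0.54 log units; beyond the scatter), which leaves compound 1, with its 1-methyl-1H-pyrazol-4-yl, apart from the other two compounds. No measurement at hand offers an explanation for this result.

On these data alone, it remains open whether an ethyl group or a longer chain on the same aromatic nitrogen would match the methyl of compound 1 or fall back towards compound 3. Also open is how a ring with a carboxylic acid or an amine on it would read at the saturated chain carbon, since the three compounds shown carry only two-hetero-atom five-membered aromatic rings there.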